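Replacing (Ethylsulfonyl)amino with (Dimethylamino)methyl

A few compounds are considered here, and "the series" means these few. Any claim that something is new, unique, unknown or untested is made for them only; others in the source may bear on it.

Within the data shown here, compound 2 `CCS(=O)(=O)Nc1cccnc1-c1ccc(C(=O)Nc2ccc(C(C)(C)C)cc2)cc1` gives the lowest of the two numbers so far in a functional assay for antagonist activity at transient receptor potential cation channel subfamily V member 1 (Rattus norvegicus) (a higher number here means a weaker inhibitor, a lower number a stronger inhibitor), at 4 nM; its nearest companion is compound 1 `Cc1cccnc1-c1ccc(C(=O)Nc2ccc(C(C)(C)C)cc2)cc1`, which in this assay gives 9 nM. Compound 3 `CN(C)Cc1cccnc1-c1ccc(C(=O)Nc2ccc(C(C)(C)C)cc2)cc1` differs from compound 2 by (dimethylamino)methyl in place of (ethylsulfonyl)amino on an aromatic carbon. Among the measured compounds shown here, the only measured step, a 2.3-fold lower number from compound 1 to compound 2 (0.35 log units; beyond the scatter), concerns a different exchange at the same place and was modest, so no measured step bears directly on this change. A small move toward a higher number is therefore expected, a 3.8-fold higher number from compound 2 to compound 3 (0.57 log units; beyond the scatter). Compound 3 is estimated at 15 nM, with a range from 4 nM to 60 nM.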

Compound 3, half-maximal inhibitory concentration: 234 nM
Estimate against measurement, compound 3: 16-fold (1.19 log units) below; the measured number lies above the stated range.
By their numbers in this assay, from the lowest: compound 2; then compound 1; then compound 3.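

The position is far from indifferent to what it carries: (dimethylamino)methyl gives a 59-fold higher number from compound 2 to compound 3 (1.77 log units; beyond the scatter), a much larger move than any seen earlier. The loss also holds against the plain methyl group, with a 26-fold higher number from compound 1 to compound 3 (1.41 log units; beyond the scatter), so adding dimethylamino to that methyl carbon is what costs activity, while (ethylsulfonyl)amino gave only a modest gain. Nothing measured here explains this loss. Still open, from the compounds shown here alone, is whether any amine on this carbon behaves the same way. An aminomethyl or a hydroxymethyl group in the same place would help separate these possibilities.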